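Methoxymethoxy on the Benzyl Arm: Expected Cytotoxicity

This account rests on a few compounds, and the source may have more. Where it says the series, first, only, none or still open, it means among the compounds named here.

Compound 1, `Cc1ccc2cc(CN(Cc3ccc(F)cc3)Cc3ccc(C(C)C)cc3)c(=O)[nH]c2c1`: in a toxicity assay on MDCK cells (Canis lupus familiaris) for cytotoxicity, read by crystal violet staining, with a stated time of 48 h (on this read-out higher numbers stand for lower toxicity in this test and lower numbers for higher toxicity in this test), compound 1 gives > 33000 nM, a limit of the assay rather than a number.
Compound 2, `Cc1ccc2[nH]c(=O)c(CN(Cc3ccccc3)Cc3ccc(C(C)(C)C)cc3)cc2c1`: compound 2 gives > 5000 nM, again a limit.
Compound 3, `CCc1ccc2[nH]c(=O)c(CN(Cc3ccc(F)cc3)Cc3ccc4ccccc4c3)cc2c1`: compound 3 gives > 5000 nM, also a limit.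

None of the three measured compounds returns an actual number in this assay. Compound 2 sits at the limit of > 5000 nM in this assay, at which 2 of the 3 values shown sit, and so stands together with compound 3 at the lower of the two limits, while compound 1 stands at the limit of > 33000 nM in this assay, at which 1 of the 3 values shown sits. Between these limits no order can be read, since every value is only a bound.

Compound 4, `COCOc1ccc(CN(Cc2ccc(C(C)(C)C)cc2)Cc2cc3cc(C)ccc3[nH]c2=O)cc1`, differs from compound 2 in one place: methoxymethoxy in place of hydrogen on an aromatic carbon. The methoxymethoxy group carries two hydrogen-bond acceptors and no charge, and it enters on an aromatic carbon of a six-membered aromatic ring of carbon only.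

Among the measured compounds shown here, no measured step between two compounds exists here, so the effect of this change on the half-maximal cytotoxic concentration has no precedent in these data. Given that all three measured compounds sit at limits, compound 4 is expected to remain weakly toxic, with the step that the limit leaves unreadable from compound 2 to compound 4 expected to be no larger than the scatter. For compound 4 the estimate is 20000 nM, within 5000 nM to 100000 nM, most likely reported again only as a limit.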

Compound 4, half-maximal cytotoxic concentration: 6400 nM
For compound 4 the middle estimate is 3.1-fold (0.49 log units) above the measured one, and the stated range covers the measured number.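

In this assay compound 2 gives > 5000 nM, which is a limit of the assay and not a number, and the step from this compound to compound 4 cannot be read. The compounds shown leave open whether methoxymethoxy in place of hydrogen on an aromatic carbon changes the half-maximal cytotoxic concentration at all, and in which direction.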